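The source may hold more compounds than are shown below. What is called first, only, known or untested is meant among the compounds shown, and "the series" means these compounds.

Working notes on the series in a functional assay on MGC-803 cells (Homo sapiens) for cytotoxicity, read by MTT assay, with a stated time of 72 h; on this read-out lower numbers stand for stronger inhibition and higher numbers for weaker inhibition. Compound 1 (`COc1ccc(C=C2C(=O)N(c3ccc(Cl)cc3)N(c3ccc(Cl)cc3)C2=O)cc1`) reads > 128000 nM, which is a limit of the assay and not a number. Compound 2 (`O=C1C(=Cc2cccc(Cl)c2)C(=O)N(c2ccc(Cl)cc2)N1c1ccc(Cl)cc1`) gives 14400 nM. Compound 3 (`COc1ccccc1C=C1C(=O)N(c2ccc(Cl)cc2)N(c2ccc(Cl)cc2)C1=O`) gives 28600 nM, and these two numbers lie within the scatter of each other: a 2.0-fold higher number from compound 2 to compound 3 (0.30 log units; within the scatter).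

Next is compound 4 (`O=C1C(=Cc2ccc(Cl)cc2Cl)C(=O)N(c2ccc(Cl)cc2)N1c1ccc(Cl)cc1`), with 2,4-dichlorophenyl in place of 2-methoxyphenyl on a double-bonded chain carbon bound to a double-bonded ring carbon.

All measured steps sit at this same place. The two larger ones are an at least 8.8-fold lower number from compound 1 to compound 2 (0.94 log units; beyond the scatter) and an at least 4.4-fold lower number from compound 1 to compound 3 (0.65 log units; beyond the scatter), and both leave the 4-methoxyphenyl of compound 1. The change at hand does not involve that group. For the measured compounds named here, the closest precedent is therefore the exchange of 3-chlorophenyl and 2-methoxyphenyl, which gave a 2.0-fold higher number from compound 2 to compound 3 (0.30 log units; within the scatter). No step beyond the scatter is expected in this assay.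

The expected step is a 1.6-fold lower number from compound 3 to compound 4 (0.20 log units; within the scatter). For compound 4 the estimated value is 18000 nM, with an expected range of 6000 nM to 55000 nM.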

Compound 4, half-maximal inhibitory concentration: > 128000 nM
Compound 4: a limit, no number; the forecaster's own chance of this, stated with the estimate: 10%; middle value at least 7.1-fold (0.85 log units) from the limit.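

In this assay the 2,4-dichlorophenyl group gives a step beyond the scatter against both neighbours with numbers: an at least 4.4-fold higher number from compound 3 to compound 4 (0.65 log units; beyond the scatter) and an at least 8.8-fold higher number from compound 2 to compound 4 (0.94 log units; beyond the scatter) on the other side, so a chlorine-bearing phenyl at this place does not by itself keep a readable number. Compound 4 reads as a limit of the assay and not a number, a reading it shares with compound 1: the limit of > 128000 nM in this assay, at which 2 of the 4 values shown sit. The step between those two limits cannot be read, and among the compounds shown the limit goes with 4-methoxyphenyl and 2,4-dichlorophenyl, while 3-chlorophenyl and 2-methoxyphenyl give numbers, with no compound against this.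

On these data alone, whether 4-chlorophenyl alone would fall with the limits or with the numbers stays open. So does the outcome for an amine or a carboxylic acid on this phenyl, and for any change away from this place on the shared core.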